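This account rests on a few compounds, and the source may have more. Where it says the series, first, only, none or still open, it means among the compounds named here.

Three compounds built on a shared core were tested in a functional assay on the whole organism (strain albino) for inhibition, with Rattus norvegicus as the target, read by paw edema, with stated times of 30 min and 3 h, at a dose of 100 mg/kg by the oral route; on this read-out lower numbers stand for less inhibition and higher numbers for more inhibition at the one dose given (going by the name of the read-out). Compound 1 `COc1ccc(C2=NN(C(=O)C(C)O[N+](=O)[O-])C(c3ccco3)C2)cc1OC` gives 42%. Compound 2 `COc1ccc(C2CC(c3ccc(OC)c(OC)c3)=NN2C(=O)C(C)O[N+](=O)[O-])c(OC)c1` carries the change 2,4-dimethoxyphenyl in place of furan-2-yl on a saturated ring carbon relative to compound 1, and in this assay compound 2 gives 56%, a step of a number 14 percentage points higher from compound 1 to compound 2 (beyond the scatter). Compound 3 `COc1ccc(C2=NN(C(=O)CNc3ccc(/C(C)=N/O)cc3)C(c3ccco3)C2)cc1OC` differs from compound 1 in more than one place, and the difference between the two cores is not broken down here; in this assay compound 3 gives 46%, which lies within the scatter of both compound 1 and compound 2.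

Compound 4 `COc1ccc(C2CC(c3ccc(OC)c(OC)c3)=NN2C(=O)CNc2ccc(/C(C)=N/O)cc2)c(OC)c1` has not yet been measured. Among the compounds with values here, it differs from compound 3 by 2,4-dimethoxyphenyl in place of furan-2-yl on a saturated ring carbon, the same kind of change as the one between compound 1 and compound 2. The surroundings are not identical: in compound 3 the saturated ring carbon is next to the ring atom that bears a large group and two ring bonds from the ring atom that bears a 3,4-dimethoxyphenyl group, whereas in compound 1 it is next to the ring atom that bears a group of 8 heavy atoms and two ring bonds from the ring atom that bears a large group. Because of a number 14 percentage points higher from compound 1 to compound 2 (beyond the scatter), a step of similar size is expected for compound 4, namely a number 14 percentage points higher from compound 3 to compound 4 (beyond the scatter). This rests on a single earlier instance, so the expectation is tentative. Compound 4 is thus estimated at 60%, with a likely range from 48% to 72%.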

Compound 4, a percentage reported as inhibition, in the whole organism at one dose (the size of the read-out at that dose, not a potency): 46%
Compound 4: middle estimate off by 14 percentage points, on the high side; the whole stated range lies above it.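

In this assay, 2,4-dimethoxyphenyl in place of furan-2-yl on the core of compound 3 gives no change at the digits printed from compound 3 to compound 4 (within the scatter), and this can be set beside the same change on the core of compound 1: the same change on two cores in this assay, a number 14 percentage points higher (beyond the scatter) from compound 1 to compound 2 and no change at the digits printed (within the scatter) from compound 3 to compound 4, 14 percentage points apart, within the scatter of two such steps

The gain seen on the core of compound 1 did not recur on the core of compound 3, but the two steps cannot be told apart, so the data show neither that the change carries from one core to the other nor that the core governs its outcome. A group of 12 heavy atoms in place of a group of 6 heavy atoms on the carbonyl carbon gives a number 10 percentage points lower from compound 2 to compound 4 (within the scatter), so this comparison also shows no separate effect of that exchange.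

The compounds shown leave open how a plain phenyl group or a short alkyl chain on the saturated ring carbon would compare with furan-2-yl and 2,4-dimethoxyphenyl on either core. They also leave open whether an amine on the chain at the carbonyl carbon would change the outcome of the same exchange.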